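Two amide variants of a shared core in a cytotoxicity test

The source may report more compounds than this note shows. Statements on the series, on what has been measured and on what is new or still open speak of the compounds shown alone.

The study compares amides built on one shared core. Compound 1 `O=C(Nc1ncc(C(Oc2ccc3cc(Br)ccc3c2)c2ccc(Cl)cc2)s1)C1CCOCC1` carries an oxane-derived amide, compound 2 `O=C(Nc1ncc(C(Oc2ccc3cc(Br)ccc3c2)c2ccc(Cl)cc2)s1)c1ccc(Br)cc1` a 4-bromophenyl amide, and compound 3 `O=C(Nc1ncc(C(Oc2ccc3cc(Br)ccc3c2)c2ccc(Cl)cc2)s1)c1ccc(F)cc1F` a 2,4-difluorophenyl amide. In an ADME assay on HepG2 2.2.15 cells (Homo sapiens) for cytotoxicity (on this read-out higher numbers stand for lower toxicity in this test and lower numbers for higher toxicity in this test), compound 1 is recorded as "not toxic" (no number reported), without a number. In this assay compound 2 reaches only a limit of the assay, > 50000 nM, so its position is known only as a bound, not as a point. Among the two entries shown, one sits at the limit of > 50000 nM in this assay, at which 1 of the 2 values shown sits, and the other has no number at all, so no measured step between compounds exists here.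

Compound 3 differs from compound 2 in one place: 2,4-difluorophenyl in place of 4-bromophenyl on a carbonyl carbon. Among the compounds with values here, with no measured step to lean on, the account expects the step from compound 2 to compound 3 to be a step that the limit leaves unreadable from compound 2 to compound 3, that is, no change beyond the scatter, in either direction. Compound 3 is therefore estimated to give 60000 nM in this assay, within a range from 25000 nM to 150000 nM, and most likely again only a limit.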

Compound 3, half-maximal cytotoxic concentration: "not toxic" (no number reported)
For compound 3 the study gives words and no number; no gap can be computed for the estimate.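

No new step can be read from compound 2 to compound 3, as compound 3 is recorded in words alone. Compound 2 gives only a limit: the limit of > 50000 nM in this assay, at which 1 of the 3 values shown sits.

The compounds shown leave open at what concentration compound 1, compound 2 or compound 3 would harm these cells in this assay, and whether the three differ at all.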